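Replacing anilino with ethyl(methyl)amino on a carbonyl carbon

This account rests on a few compounds, and the source may have more. Where it says the series, first, only, none or still open, it means among the compounds named here.

Measured so far in a physicochemical assay for lipophilicity, at pH 7.4 (a lower number here means a more polar compound, a higher number a more lipophilic compound), are three compounds
- compound 1 `O=C(NC1CC1)C1CCN(c2cncnc2-c2ccccc2)CC1` gives 1.8
- compound 2 `CNC(=O)C1CCN(c2cncnc2-c2ccccc2)CC1` gives 1.4
- compound 3 `O=C(Nc1ccccc1)C1CCN(c2cncnc2-c2ccccc2)CC1` gives 2.7

Compound 3 has the highest number of these three in this assay and sits clearly above the other two. The next compound is compound 4 `CCN(C)C(=O)C1CCN(c2cncnc2-c2ccccc2)CC1` and it has not been measured yet. The structural change is ethyl(methyl)amino in place of anilino on a carbonyl carbon so that ethyl(methyl)amino stands in place of anilino on a carbonyl carbon.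

For the measured compounds named here, three measured steps bear on this. Exchanging cyclopropyl for phenyl gave a number 0.90 log units higher from compound 1 to compound 3 (beyond the scatter) and phenyl in place of methyl gave a number 1.30 log units higher from compound 2 to compound 3 (beyond the scatter) as the largest step seen here. Methyl in place of cyclopropyl gave a number 0.40 log units lower from compound 1 to compound 2 (beyond the scatter) and so shows how much the non-aromatic groups differ from each other. Compound 4 has no phenyl, so its number is expected to land nearer compound 1 at 1.8 than compound 3. Going by the values given here, no measured compound carries ethyl(methyl)amino, which leaves the size uncertain. The expected change is a number 0.80 log units lower from compound 3 to compound 4 (beyond the scatter) and this would be a fall of modest size. The estimated value for compound 4 is 1.9 within an expected range of 1.4 to 2.4 on this reasoning.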

Compound 4, distribution coefficient: 2.1
Beside the measured number, compound 4's estimate is 0.20 log units below it; low and high end bracket the measured number.
By their numbers in this assay, from the lowest: compound 2; then compounds 1 and 4 (each within the scatter of the next); then compound 3.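

In this assay, for the compounds shown here, compound 4 is the first compound here without an amide hydrogen at this position, and the exchange of anilino for ethyl(methyl)amino gives a number 0.60 log units lower from compound 3 to compound 4 (beyond the scatter) in a modest step. Putting ethyl in place of the amide hydrogen gives a number 0.70 log units higher from compound 2 to compound 4 (beyond the scatter) and so shows that a change at this position can move the number clearly without bringing in any ring, while the comparison with the cyclopropylamino compound gives a number 0.30 log units higher from compound 1 to compound 4 (within the scatter) and leaves those two groups on the carbonyl carbon indistinguishable in this assay. Compound 3, with anilino, therefore remains clearly above all three compounds without a phenyl, and nothing measured here gives a reason for any of these steps.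

The compounds shown do not separate the loss of the amide hydrogen from the addition of the ethyl group, and dimethylamino on the same carbonyl carbon would bear directly on that question. They also leave open how a ring-closed group such as morpholine or pyrrolidine, a longer chain such as butyl, or a chain ending in an amine would read at this position.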